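A few compounds are considered here, and "the series" means these few. Any claim that something is new, unique, unknown or untested is made for them only; others in the source may bear on it.

Working notes, measured in a functional assay on HL-60 cells (Homo sapiens) for antiproliferative activity, read by MTT assay, with a stated time of 72 h; a lower number here means a stronger inhibitor, a higher number a weaker inhibitor:

- compound 1 `CCn1cc(C(=O)O)c(=O)c2cc(F)c(N3CCN(C(=N)NS(=O)(=O)c4ccccc4Cl)CC3)cc21`: 43 nM
- compound 2 `CCn1cc(C(=O)O)c(=O)c2cc(F)c(N3CCN(C(=N)NS(=O)(=O)c4ccccc4)CC3)cc21`: 43 nM
- compound 3 `CCn1cc(C(=O)O)c(=O)c2cc(F)c(N3CCN(C(=N)NS(=O)(=O)c4ccc(Cl)cc4)CC3)cc21`: 43 nM

Compound 3 stands level with compound 1 and compound 2 on these numbers. Compound 4 `CCn1cc(C(=O)O)c(=O)c2cc(F)c(N3CCN(C(=N)NS(=O)(=O)c4ccc(C)cc4)CC3)cc21` carries methyl in place of chloro on an aromatic carbon, para to a large group: methyl in place of chloro on an aromatic carbon.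

Within the data shown here, three measured steps bear on this change. Chloro in place of hydrogen on an aromatic carbon gives no change at the digits printed from compound 2 to compound 3 (within the scatter). Hydrogen in place of chloro gives no change at the digits printed from compound 1 to compound 2 (within the scatter). 4-Chlorophenyl in place of 2-chlorophenyl gives no change at the digits printed from compound 1 to compound 3 (within the scatter). None of these steps lies beyond the scatter, so this aryl group has shown no sensitivity so far. Among the measured compounds shown here, no methyl-bearing compound has been measured, which leaves some uncertainty.

In this assay, no shift beyond the scatter is expected, and the estimated step is no change at the digits printed from compound 3 to compound 4 (within the scatter). The estimate for compound 4 is 43 nM, with an expected range of 20 nM to 95 nM.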

Compound 4, half-maximal inhibitory concentration: 43 nM
Estimate against measurement, compound 4: no gap at the digits printed; low and high end bracket the measured number.
By their numbers in this assay, from the lowest: compounds 1, 2, 3 and 4 (each within the scatter of the next).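

Methyl enters this place in this assay without moving the read-out beyond the scatter, giving no change at the digits printed from compound 3 to compound 4 (within the scatter). The same holds for the comparisons with the unsubstituted phenyl and the 2-chlorophenyl members, with no change at the digits printed from compound 2 to compound 4 (within the scatter) and no change at the digits printed from compound 1 to compound 4 (within the scatter), so a carbon substituent now joins chloro and hydrogen among the groups this aryl ring tolerates at the digits printed. No supporting measurement is available to account for this flat result.

As far as these compounds go, whether an amine, a carboxylic acid or a longer chain such as butyl at this place would shift the value remains open. Every compound shown also keeps an aryl ring on the sulfonyl sulfur, so the effect of a cyclohexyl group there is equally open.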